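This account rests on a few compounds, and the source may have more. Where it says the series, first, only, none or still open, it means among the compounds named here.

Measured in a functional assay on IGROV-1 cells (Homo sapiens) for cytotoxicity, read by sulforhodamine B assay, with a stated time of 48 h, tested at 0.001 uM; on this read-out higher numbers stand for a weaker effect at the one concentration tested and lower numbers for a stronger effect:
- compound 1 `COc1cc(C)cc(-c2c(-c3ccnc(-c4ccc(C(C)=O)cc4)c3)cnn2CC#N)c1` gives 107%
- compound 2 `COc1cc(C)cc(-c2nn(CC#N)cc2-c2ccc(-c3cccc(C(C)=O)c3)nc2)c1` gives 106%
- compound 3 `Cc1cc(O)cc(-c2nn(CC#N)cc2-c2ccnc(-c3ccc(Oc4ccccc4)cc3)c2)c1` gives 98%

Compound 1 holds the highest of the three numbers, but neither of the other two is separated from it by more than the usual scatter: compound 2 sits nearest, compound 3 furthest, and both gaps remain inside that scatter. The three numbers together describe a set that shows essentially no effect at the single concentration used, with nothing to tell the compounds apart.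

The next compound, compound 4 `COc1cc(C)cc(-c2c(-c3ccnc(-c4ccc(N(C)C)cc4)c3)cnn2CC#N)c1`, keeps the whole of compound 1 apart from one place: dimethylamino in place of acetyl on an aromatic carbon. Going by the values given here, no pair of measured compounds differs in exactly this way, so the series gives no direct reading of what such a swap does in this assay. With all three measured numbers sitting at the same level, the step from compound 1 to compound 4 is expected to amount to nothing beyond the scatter, as the estimated step of a number 3 percentage points lower from compound 1 to compound 4 (within the scatter) shows. Compound 4 is accordingly expected to give 104% in this assay, with a range from 92% to 114%.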

Compound 4, a percentage reported as activity, at one concentration (the size of the read-out at that concentration, not a potency): 95%
Beside the measured number, compound 4's estimate is 9 percentage points above it, within the range that was stated.
By their numbers in this assay, from the lowest: compounds 4, 3, 2 and 1 (each within the scatter of the next, the first and the last beyond it).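

Going by these compounds alone, the step of a number 12 percentage points lower from compound 1 to compound 4 (beyond the scatter) in this assay is the first single-place comparison, and it shows that the read-out can respond to a change on this six-membered aromatic ring of carbon only, though the step is modest. Acetyl and dimethylamino have the same count of heavy atoms and of hydrogen-bond acceptors, so those counts do not account for the difference between compound 1 and compound 4. Nothing available explains the step.

Open, going by these compounds, is whether a primary amine, a carboxylic acid or a morpholine ring at this position would give a larger step or none. Also open, on these data alone, is whether dimethylamino would give a similar step on the core of compound 2 or of compound 3.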